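Swapping Trifluoromethyl for Methoxy in a Hydroxamic Acid Series

The compounds below may be only part of what the source reports. "The series", "measured", "known", "first", "only" and "open" are said of these compounds alone.

Three hydroxamic acids built on one shared core have been tested in a functional assay on PC-3 cells (Homo sapiens) for antiproliferative activity; on this read-out lower numbers stand for stronger inhibition of growth and higher numbers for weaker inhibition of growth. Compound 1 `O=C(CCC1=CCN(Cc2ccc(C(F)(F)F)cc2)C1=O)NO` gives 4360 nM, the highest of the three numbers. Compound 2 `COc1cccc(CN2CC=C(CCC(=O)NO)C2=O)c1` gives 3890 nM, and compound 3 `COc1ccccc1CN1CC=C(CCC(=O)NO)C1=O` gives 3560 nM; both lie within the usual scatter of compound 1, so no order among the three can be claimed. Compound 4 `COc1ccc(CN2CC=C(CCC(=O)NO)C2=O)cc1` has not yet been measured in this assay. It differs from compound 1 by methoxy in place of trifluoromethyl on an aromatic carbon. Because the methoxy-bearing compound 2 gives 3890 nM and the methoxy-bearing compound 3 gives 3560 nM and both sit within the scatter of compound 1, no step beyond the scatter is expected in either direction. For compound 4 the expected value is 3600 nM, within a range from 1600 nM to 8000 nM. This corresponds to an expected step of a 1.2-fold lower number from compound 1 to compound 4 (0.08 log units; within the scatter).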

Compound 4, concentration for 50% growth inhibition: 3120 nM
Beside the measured number, compound 4's estimate is 1.2-fold (0.06 log units) above it; measured number inside the range.
By their numbers in this assay, from the lowest: compounds 4, 3, 2 and 1 (each within the scatter of the next).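

In this assay, methoxy in place of trifluoromethyl, on an aromatic carbon para to a large group, gives a 1.4-fold lower number from compound 1 to compound 4 (0.15 log units; within the scatter) and so leaves the read-out within the scatter. The earlier compounds shown here offered no such reading, as no two of them differed in one place. Nothing at hand bears on what lies behind this result.

From the compounds shown here alone, whether an amine, a carboxylic acid or a nitrile at this position would move the number beyond the scatter stays open. So does the effect of a longer chain there.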